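A dichlorophenyl step starting from a limit

The source may hold more compounds than are shown below. What is called first, only, known or untested is meant among the compounds shown, and "the series" means these compounds.

Measured so far in a functional assay on K562 cells (Homo sapiens) for antiproliferative activity, read by MTT assay, with a stated time of 72 h; a lower number here means a stronger inhibitor, a higher number a weaker inhibitor
compound 1 `COc1cc(-c2ncnn2-c2cccc(F)c2)cc(OC)c1OC` gives > 10000 nM as a limit
compound 2 `COc1cc(-c2ncnn2-c2ccc(F)cc2)cc(OC)c1OC` gives > 10000 nM as a limit
compound 3 `COc1cc(-c2ncnn2-c2ccccc2)cc(OC)c1OC` gives > 10000 nM as a limit

In this assay compound 3 stands only at the limit > 10000 nM and has no number. The whole set so far is summed up by the limit of > 10000 nM in this assay, at which 3 of the 3 values shown sit, and offers no measured value to start from.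

Going by the values given here, compound 4 `COc1cc(-c2ncnn2-c2ccc(Cl)c(Cl)c2)cc(OC)c1OC` keeps the shared core and carries 3,4-dichlorophenyl in place of phenyl on an aromatic nitrogen as its only change from compound 3.

The fluoro changes on that same aryl group are the measured steps that bear on it. They give a step that the two limits leave unreadable from compound 1 to compound 3 and a step that the two limits leave unreadable from compound 2 to compound 3 and a step that the two limits leave unreadable from compound 1 to compound 2 with no size to read in any of them. They therefore point in no direction, and no step beyond the scatter is expected. The expected change is a step that the limit leaves unreadable from compound 3 to compound 4 as an estimate resting on limits alone.

For compound 4 the estimated value is 15000 nM with an expected range from 5000 nM to 40000 nM in this assay and a report as a limit is likely.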

Compound 4, half-maximal inhibitory concentration: > 10000 nM
Compound 4 gave a limit, no number; the forecaster's own chance of this, stated with the estimate: 80%; the middle value does not contradict the limit.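

Compound 4 gives > 10000 nM as a limit and not a number in this assay and so adds no readable step from compound 1, compound 2 or compound 3, and the set stays summed up by one limit: the limit of > 10000 nM in this assay, at which 4 of the 4 values shown sit. The compounds shown leave open whether any aryl group on that aromatic nitrogen gives a measured value in this assay at all.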